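Replacing 1H-pyrazol-1-yl with pyrrolidin-1-yl: clearance expected for compound 4

The compounds below may be only part of what the source reports. "The series", "measured", "known", "first", "only" and "open" are said of these compounds alone.

Results so far in an ADME assay on microsomes from liver (Rattus norvegicus) for metabolic stability (on this read-out higher numbers stand for fast clearance and lower numbers for slow clearance), are:
Compound 1 `CNc1nc(NC2(C#N)CCCCC2)nc(-n2cccn2)n1` gives 103 mL/min/kg
Compound 2 `CNc1nc(NC2(C#N)CCCCCC2)nc(-n2cncn2)n1` gives 276 mL/min/kg
Compound 3 `CCCC(C#N)(CC)Nc1nc(NC)nc(-n2cncn2)n1` gives 29 mL/min/kg

Compound 1 holds the second highest of these three numbers. Compound 2 lies above it and compound 3 lies below it, and both gaps are beyond the scatter. The next compound to be read in this assay is compound 4 `CNc1nc(NC2(C#N)CCCCC2)nc(N2CCCC2)n1`, which carries pyrrolidin-1-yl in place of 1H-pyrazol-1-yl on an aromatic carbon of the core of compound 1, opposite the ring nitrogen. The counted difference is pyrrolidin-1-yl in place of 1H-pyrazol-1-yl on an aromatic carbon and the rest of the structure stays the same.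

Going by the values given here, no measured pair isolates this exchange, since compound 2 and compound 3 each differ from compound 1 in more than one place. The direction of the step is therefore a judgement and not a trend read from the data. A modest rise in the number is expected, with no firm expectation that it will clear the scatter. The expected change is a 1.6-fold higher number from compound 1 to compound 4 (0.19 log units; within the scatter) in this estimate. For compound 4 the estimated value is 160 mL/min/kg, with an expected range from 60 mL/min/kg to 400 mL/min/kg.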

Compound 4, clearance: > 276 mL/min/kg
Compound 4: no number, only a limit; the forecaster's own chance of this, stated with the estimate: 2%; middle value at least 1.7-fold (0.23 log units) from the limit.
By their numbers in this assay, from the lowest: compound 3; then compound 1; then compound 2.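

In this assay, the exchange of 1H-pyrazol-1-yl for pyrrolidin-1-yl on the aromatic carbon opposite the ring nitrogen is the first change among these compounds that stands alone in one place, and it reads as an at least 2.6-fold higher number from compound 1 to compound 4 (0.42 log units; beyond the scatter). Compound 4 has no number here, only a limit of the assay: the limit of > 276 mL/min/kg in this assay, at which 1 of the 4 values shown sits. The group at this position therefore matters to the read-out, since a five-membered non-aromatic ring with one hetero atom, entering where a five-membered aromatic ring with two hetero atoms stood, moves clearance upward beyond the scatter, although the full size of that rise stays unread.

This single exchange cannot separate the loss of aromaticity from the loss of a ring nitrogen, and a morpholine or a dimethylamino group at the same position would be needed to tell how far the rise extends across other amines. As far as these compounds go, it also remains open whether the same exchange would carry the same direction on the open-chain nitrile-bearing group of compound 3.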